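Dihydroindole in place of pyrrolidine on compound 1

This account rests on a few compounds, and the source may have more. Where it says the series, first, only, none or still open, it means among the compounds named here.

Measured compounds in a functional assay on A549 cells (Homo sapiens) for inhibition, read by MTT assay, with a stated time of 72 h, tested at 20 uM; a lower number here means less inhibition, a higher number more inhibition at the concentration tested (going by the name of the read-out):
Compound 1 `CN(c1ccc(Oc2ncnc3ccsc23)cc1)c1nccc(N2CCCC2)n1` gives 63.9%.
Compound 2 `CN(c1ccc(Oc2ncnc3sccc23)cc1)c1nccc(N2CCCC2)n1` gives 55.5%.
Compound 3 `CN(c1ccc(Oc2ncnc3sccc23)cc1)c1nccc(N2CCCCC2)n1` gives 51.9%.

Compound 1 holds the highest of the three numbers. Its nearest neighbour is compound 2, with a number 8.4 percentage points lower from compound 1 to compound 2 (within the scatter), while the gap to compound 3 is beyond the scatter. The unmeasured compound 4 `CN(c1ccc(Oc2ncnc3ccsc23)cc1)c1nccc(N2CCc3ccccc32)n1` differs from compound 1 by 2,3-dihydro-1H-indol-1-yl in place of pyrrolidin-1-yl on an aromatic carbon.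

Among the measured compounds shown here, the only measured step at this position is a number 3.6 percentage points lower from compound 2 to compound 3 (within the scatter), in which a larger saturated ring replaced the pyrrolidin-1-yl and the read-out stayed essentially where it was. For the measured compounds named here, no measured pair exchanges the pyrrolidin-1-yl for a group that carries a further aromatic ring, so the present change is not covered directly and the estimate rests on the one small step available. Since compound 2 to compound 3 moved little, a further change at this position is expected to move the number by no more than the scatter, with the larger entering group allowed a modest downward drift.

Compound 4 is therefore expected to give 58%, in a range from 38% to 76%. The estimated step is a number 5.9 percentage points lower from compound 1 to compound 4 (within the scatter), which is expected to lie within the scatter of the measured values.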

Compound 4, a percentage reported as inhibition, at one concentration (the size of the read-out at that concentration, not a potency): 58.2%
Beside the measured number, compound 4's estimate is 0.2 percentage points below it; measured number inside the range.
By their numbers in this assay, from the lowest: compounds 3, 2, 4 and 1 (each within the scatter of the next, the first and the last beyond it).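

In this assay, exchanging pyrrolidin-1-yl for 2,3-dihydro-1H-indol-1-yl on the aromatic carbon of the six-membered aromatic ring with 2 nitrogen gives a number 5.7 percentage points lower from compound 1 to compound 4 (within the scatter), so on the core of compound 1 this place accepts a group carrying a further six-membered aromatic ring of carbon only without a change beyond the scatter. The earlier step at this place, a number 3.6 percentage points lower from compound 2 to compound 3 (within the scatter), only enlarged a saturated ring and did so on a different core; the two steps now cover a saturated and a fused aromatic replacement, and neither goes beyond the scatter. Nothing available bears on why the read-out holds across this change.

From the compounds shown here alone, whether a morpholin-4-yl ring or an open-chain dimethylamino group in the same place would also stay within the scatter remains open, as does the effect of a fluorine or methoxy group on the added aromatic ring. Going by these compounds, it is also open whether 2,3-dihydro-1H-indol-1-yl behaves the same way on the core of compound 2, and since the read-out is taken at a single concentration, these steps say nothing about potency.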